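The compounds below may be only part of what the source reports. "The series", "measured", "known", "first", "only" and "open" are said of these compounds alone.

In an assay on HEK293 cells for negative allosteric modulation of metabotropic glutamate receptor 5 (Homo sapiens), read by FLIPR, with a stated time of 1 h (a higher number here means a weaker inhibitor, a lower number a stronger inhibitor), compound 2 `CN1CCc2nc(C#Cc3ccccc3)sc2C1` gives only a limit, > 10000 nM. Compound 1 `O=C1NCCc2nc(C#Cc3ccccc3)sc21` likewise reaches only a limit in this assay, > 10000 nM. Compound 2 therefore stands at the edge of what this assay can report, as does compound 1 (the limit of > 10000 nM in this assay, at which 2 of the 3 values shown sit). Compound 3 `Fc1cccc(C#Cc2nc3c(s2)CN(C2CCC2)CC3)c1`, which carries a cyclobutyl group and a fluorine, gives 200 nM in this assay. Compound 4 `O=C(C1CCC1)N1CCc2nc(C#Cc3ccccc3)sc2C1` differs from compound 2 in one place (cyclobutylcarbonyl in place of methyl on an amine nitrogen in a ring). For the measured compounds named here, no measured pair shows this exact step, so its size can only be estimated; compound 3, with 200 nM, suggests that a larger group on that nitrogen is tolerated. A shift toward stronger inhibition is expected, an at least 6.6-fold lower number from compound 2 to compound 4 (0.82 log units; beyond the scatter). For compound 4 the value in this assay is estimated at 1500 nM, between 300 nM and 8000 nM.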

Compound 4, half-maximal inhibitory concentration: 370 nM
For compound 4 the middle estimate is 4.1-fold (0.61 log units) above the measured one, within the range that was stated.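

On the amine nitrogen in the ring, cyclobutylcarbonyl in place of methyl gives an at least 27-fold lower number from compound 2 to compound 4 (1.43 log units; beyond the scatter). For the compounds shown here, this is the first change in a single place, and it shows that this nitrogen can turn a compound without a measurable value into a measurable inhibitor in this assay. The full size of the step stays unknown because compound 2 reaches only a limit: the limit of > 10000 nM in this assay, at which 2 of the 4 values shown sit.

Still open, as far as these compounds go, is whether the carbonyl, the four-membered ring or both account for the step. An acetyl group or a simple benzoyl group at this nitrogen would help separate these parts.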